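Aryl amide variation on a flavonol scaffold

This account rests on a few compounds, and the source may have more. Where it says the series, first, only, none or still open, it means among the compounds named here.

In a functional assay on HCC1937 cells (Homo sapiens) for antiproliferative activity, read by CCK-8 assay, with a stated time of 72 h (on this read-out higher numbers stand for weaker inhibition and lower numbers for stronger inhibition), compound 2 `O=C(Nc1cccc(-c2oc3cc(-c4ccc(F)cc4)ccc3c(=O)c2O)c1)c1ccc(Br)cc1` gives 8630 nM, the lowest number of the three measured analogues. Compound 1 `Cc1ccccc1C(=O)Nc1cccc(-c2oc3cc(-c4ccc(F)cc4)ccc3c(=O)c2O)c1` sits within the scatter of it at 9900 nM, with a 1.1-fold lower number from compound 1 to compound 2 (0.06 log units; within the scatter). Compound 3 `COc1cccc(C(=O)Nc2cccc(-c3oc4cc(-c5ccc(F)cc5)ccc4c(=O)c3O)c2)c1` gives 18900 nM, and the step is a 2.2-fold higher number from compound 2 to compound 3 (0.34 log units; beyond the scatter). Compound 4 `O=C(Nc1cccc(-c2oc3cc(-c4ccc(F)cc4)ccc3c(=O)c2O)c1)c1ccc(Cl)nc1` differs from compound 2 by 6-chloropyridin-3-yl in place of 4-bromophenyl on a carbonyl carbon. Both measured steps on this carbonyl carbon were small, and none of them involves a ring with a hetero atom, so the data give little to go on. Compound 4 is therefore expected to land near compound 2, with a 1.1-fold higher number from compound 2 to compound 4 (0.04 log units; within the scatter) and no step beyond the scatter. The estimate for compound 4 is 9500 nM, ranging from 4000 nM to 22000 nM.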

Compound 4, half-maximal inhibitory concentration: 7550 nM
Compound 4: the middle estimate sits 1.3-fold (0.10 log units) above what was measured; low and high end bracket the measured number.
By their numbers in this assay, from the lowest: compounds 4, 2, 1 and 3 (each within the scatter of the next, the first and the last beyond it).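

The 6-chloropyridin-3-yl group, the only ring with a hetero atom on this carbonyl carbon among these compounds, keeps the number in this assay in the same range as the carbon-only rings, with a 1.1-fold lower number from compound 2 to compound 4 (0.06 log units; within the scatter) and a 1.3-fold lower number from compound 1 to compound 4 (0.12 log units; within the scatter) as its steps. Only the comparison with the 3-methoxyphenyl group exceeds the scatter, and modestly, with a 2.5-fold lower number from compound 3 to compound 4 (0.40 log units; beyond the scatter) as the step. No measurement offers an explanation for these differences.

The change swaps a ring carbon for nitrogen and bromine for chlorine together, so neither can be judged alone. Going by these compounds, whether a plain pyridin-3-yl ring, a saturated piperidine ring or a carboxylic acid on the ring would hold this level remains open.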